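A few compounds are considered here, and "the series" means these few. Any claim that something is new, unique, unknown or untested is made for them only; others in the source may bear on it.

Working notes on the series. Compound 1 `Cc1cccc(-n2nc(-c3ccccc3)c(C=O)c2/N=C/N(C)C)c1` carries an aldehyde on the shared core and a dimethylamino amidine; in a functional assay on NPC-TW01 cells (Homo sapiens) for inhibition, read by MTT assay, with a stated time of 72 h (on this read-out higher numbers stand for weaker inhibition of growth and lower numbers for stronger inhibition of growth), compound 1 gives 8900 nM. Compound 2 `CN/C=N/c1cc(-c2ccccc2)nn1-c1ccccc1` lacks the aldehyde and carries a methylamino formamidine. In this assay compound 2 reaches only the limit of the assay, > 50000 nM. Compound 3 `CN/C(C)=N/c1cc(-c2ccccc2)nn1-c1ccccc1` carries a methylamino acetamidine in place of that formamidine. In this assay compound 3 likewise reaches only the limit, > 50000 nM. The step that the two limits leave unreadable from compound 2 to compound 3 is therefore not readable in size. Among the compounds with values here, two of the three values sit at the limit of > 50000 nM in this assay, at which 2 of the 3 values shown sit, so compound 3 stands at the floor of what the read-out resolves, with compound 1 the only member that returns a number.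

Compound 4 `C/C(=N\c1cc(-c2ccccc2)nn1-c1ccccc1)N(C)C` differs from compound 3 by methyl in place of hydrogen on an amine nitrogen, that is methylamino to dimethylamino. Within the data shown here, no measured step isolates this change: the only measured step, a step that the two limits leave unreadable from compound 2 to compound 3, is itself unreadable, and compound 4 differs in more than one place from compound 1, whose value of 8900 nM therefore gives no reading on the methyl alone. With compound 3 at the limit, the step that the limit leaves unreadable from compound 3 to compound 4 is expected to stay within the scatter. Compound 4 is accordingly estimated at 60000 nM in this assay, within 15000 nM to 250000 nM, and most likely reported again only as a limit.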

Compound 4, concentration for 50% growth inhibition: > 50000 nM
Compound 4: only a limit was reported (the forecaster's own chance of this, stated with the estimate: 70%); the middle value is on the limit's open side.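

Within the data shown here, compound 2, compound 3 and compound 4 all return only a limit in this assay, so no step among them can be read: the limit of > 50000 nM in this assay, at which 3 of the 4 values shown sit.

The compounds shown leave open whether methyl in place of hydrogen on an amine nitrogen changes growth inhibition at all, and which of the several differences sets compound 1 apart.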